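Swapping the carbonyl aryl group at the assay limit

The source may report more compounds than this note shows. Statements on the series, on what has been measured and on what is new or still open speak of the compounds shown alone.

In a functional assay on Hs-578T cells (Homo sapiens) for inhibition, read by sulforhodamine B assay, with a stated time of 48 h (a lower number here means that less compound is tolerated, a higher number that more compound is tolerated), compound 1 (`COc1ccc(-c2cc(/C=C/C(=O)c3ccc(N)cc3)[nH]n2)cc1`) reads > 100000 nM as a limit of the assay, not a number. Compound 2 (`COc1cc(-c2cc(/C=C/C(=O)c3ccc(Cl)c(Cl)c3)[nH]n2)cc(OC)c1OC`) reads > 100000 nM and this too is a limit, not a number. Compound 2 therefore stands only at the limit of > 100000 nM in this assay, at which 2 of the 2 values shown sit, and has no numbered position in the series.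

The step to compound 3 (`COc1ccc(C(=O)/C=C/c2cc(-c3cc(OC)c(OC)c(OC)c3)n[nH]2)cc1`) puts 4-methoxyphenyl in place of 3,4-dichlorophenyl on a carbonyl carbon and leaves the rest of compound 2 unchanged. Among the measured compounds shown here, no measured pair shows what a change at this place does, so no step beyond the usual scatter is expected in this assay in either direction. For the measured compounds named here, this expectation rests on compound 2 with its limit of > 100000 nM as the only anchor for the step. A report as a limit is again the likeliest outcome for compound 3. The expected step is a number no higher from compound 2 to compound 3 (the limit leaves the size open) on this estimate. For compound 3 the estimate is 100000 nM with an expected range from 40000 nM to 200000 nM in the same read-out.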

Compound 3, concentration lethal to 50% of the cells: > 100000 nM
Compound 3: a limit, no number (the forecaster's own chance of this, stated with the estimate: 75%); the middle value lies on the limit itself.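

In this assay compound 3 reads > 100000 nM, a limit of the assay and not a number. Compound 2 is a limit too, so no step can be read between compound 2 and compound 3. The compounds shown leave open what 4-methoxyphenyl in place of 3,4-dichlorophenyl on a carbonyl carbon does, and how any of them rank: the limit of > 100000 nM in this assay, at which 3 of the 3 values shown sit.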